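The source may hold more compounds than are shown below. What is called first, only, known or untested is meant among the compounds shown, and "the series" means these compounds.

Compound 1 `Cc1noc(C)c1S(=O)(=O)N1CCC(N2CCC(C)CC2)CC1` sits at a limit in an ADME assay on HCT-116 cells (Homo sapiens) for cytotoxicity, read by CellTiter-Glo, with a stated time of 72 h (a lower number here means a stronger inhibitor, a higher number a weaker inhibitor), where compound 1 gives > 10000 nM (the limit of > 10000 nM in this assay, at which 1 of the 2 values shown sits). Compound 2 `CC1CCN(C2CCN(S(=O)(=O)c3ccccc3-c3ccc(C(F)(F)F)cc3)CC2)CC1` likewise reaches only a limit, as compound 2 gives > 5000 nM in this assay (the limit of > 5000 nM in this assay, at which 1 of the 2 values shown sits). Neither of the two values is a number, so no order between them can be read. Compound 3 `CC1CCN(C2CCN(S(=O)(=O)c3cncc(Br)c3)CC2)CC1` differs from compound 1 by 5-bromopyridin-3-yl in place of 3,5-dimethyl-1,2-oxazol-4-yl on a sulfonyl sulfur. In this assay the expected step is a step that the limit leaves unreadable from compound 1 to compound 3, none beyond the scatter, with a limit again the likely outcome. Compound 3 is estimated at 12000 nM in this assay, with a range from 3000 nM to 40000 nM.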

Compound 3, half-maximal inhibitory concentration: > 10000 nM
Compound 3: no number, only a limit; the forecaster's own chance of this, stated with the estimate: 80%; the middle value is on the limit's open side.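

For the compounds shown here, compound 1 and compound 3 both reach only a limit in this assay, so no step between them can be read. The compounds shown leave open whether any group on a sulfonyl sulfur gives a measured number in this assay.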